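The source may report more compounds than this note shows. Statements on the series, on what has been measured and on what is new or still open speak of the compounds shown alone.

In an assay on cells for displacement of a labelled ligand from adenosine receptor A1 (Homo sapiens), read by scintillation counting and radioligand binding, with a stated time of 60 min, tested at 10 uM (on this read-out lower numbers stand for less inhibition and higher numbers for more inhibition at the one concentration tested (going by the name of the read-out)), compound 1 `Cn1cnc2c(N3CCCCC3)nc(-c3cccc(O)c3)nc21` gives 78.5%, and compound 2 `CN1CCN(c2nc(-c3cccc(Cl)c3)nc3c2ncn3C)CC1` gives 45.7%. For compound 3 `Clc1cccc(-c2nc(N3CCCCC3)c3nc[nH]c3n2)c1` the this assay reports only a limit, > 80%, so its true value is not known as a number. Within the data shown here, that limit is the one value of the three that sits at the limit of > 80% in this assay, at which 1 of the 3 values shown sits. Compound 4 `Cn1cnc2c(N3CCCCC3)nc(-c3cccc(Cl)c3)nc21` differs from compound 3 by methyl in place of hydrogen on an aromatic nitrogen. Among the measured compounds shown here, no two measured compounds differ in that one place alone, so the size of the step is open. The step expected here, in this assay, is a number at least 5 percentage points lower from compound 3 to compound 4 (that floor lies within the scatter), which would be a small loss, close to the scatter. Compound 4 is therefore expected to give about 75% in this assay, most likely between 55% and 85%. This rests on compound 1, which carries the same methyl and gives 78.5%.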

Compound 4, a percentage reported as inhibition, at one concentration (the size of the read-out at that concentration, not a potency): 22.4%
Beside the measured number, compound 4's estimate is 52.6 percentage points above it; measured number below the stated range.
By their numbers in this assay, from the lowest: compound 4; then compound 2; then compound 1. At a limit, above all of these: compound 3.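

In this assay, methyl in place of hydrogen on the aromatic nitrogen gives a number at least 57.6 percentage points lower from compound 3 to compound 4 (beyond the scatter) and shows that this small change can matter greatly. With that methyl kept, chloro in place of hydroxy gives a number 56.1 percentage points lower from compound 1 to compound 4 (beyond the scatter) and piperidin-1-yl in place of 4-methylpiperazin-1-yl gives a number 23.3 percentage points lower from compound 2 to compound 4 (beyond the scatter) in the same assay, so the other groups also count. Compound 3 stands at a limit of the read-out: the limit of > 80% in this assay, at which 1 of the 4 values shown sits.

Still open, as far as these compounds go, is whether a longer chain such as ethyl on that nitrogen would lower the number further. Also open, from the compounds shown here alone, is whether hydrogen in place of the methyl of compound 1 would change its number at all.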